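A few compounds are considered here, and "the series" means these few. Any claim that something is new, unique, unknown or untested is made for them only; others in the source may bear on it.

Compound 1 `COc1ccc(-c2c(Br)c(=O)c3c(OC)cc(OC)cc3n2S(=O)(=O)c2ccc(OC)cc2)cc1`: 2580 nM
Compound 2 `COC(=O)c1cc(=O)c2c(OC)cc(OC)cc2n1S(=O)(=O)c1ccc(C)cc1`: 6000 nM
Compound 3 `COc1ccc(-c2cc(=O)c3c(OC)cc(OC)cc3n2S(=O)(=O)c2cccc([N+](=O)[O-])c2)cc1`: a limit only, > 39600 nM

All three numbers come from a functional assay on KOPN-8 cells (Homo sapiens) for antiproliferative activity, with a stated time of 72 h; on this read-out lower numbers stand for an effect already at smaller amounts and higher numbers for an effect only at larger amounts of compound. Compound 1 and compound 2 give numbers within the measured window. Compound 3 stands apart: it sits at the limit of this assay, (the limit of > 39600 nM in this assay, at which 1 of the 3 values shown sits), so for compound 3 only a floor is known and no exact number.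

Compound 4 `COc1ccc(-c2cc(=O)c3c(OC)cc(OC)cc3n2S(=O)(=O)c2cc(Cl)cc(Cl)c2O)cc1` is the compound still to be measured. It differs from compound 3 in one place: 3,5-dichloro-2-hydroxyphenyl in place of 3-nitrophenyl on a sulfonyl sulfur. Among the measured compounds shown here, no pair of measured compounds here differs in just one place, so no measured step tells how large a change of this kind is in this assay. For the measured compounds named here, the only guide is that compound 1 and compound 2 do show measurable numbers, and that compound 3 does not.

Compound 4 is therefore expected to land around 15000 nM, within a range of 3000 nM to 60000 nM. This estimate means a step from compound 3 to compound 4 of an at least 2.6-fold lower number from compound 3 to compound 4 (0.42 log units; beyond the scatter), expected to run toward an effect at smaller amounts, though with a real chance that only a limit is reported again.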

Compound 4, half-maximal effective concentration: > 37900 nM
Compound 4 ended at the assay's limit (the forecaster's own chance of this, stated with the estimate: 40%); middle value at least 2.5-fold (0.40 log units) from the limit.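

In this assay compound 3 and compound 4 each give only a limit and no exact number, so the size of the step between them cannot be read. The compounds shown leave open whether 3,5-dichloro-2-hydroxyphenyl in place of 3-nitrophenyl on a sulfonyl sulfur changes the antiproliferative effect at all.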